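This account rests on a few compounds, and the source may have more. Where it says the series, first, only, none or still open, it means among the compounds named here.

Measured compounds:
compound 1, `O=S(=O)(CC1=NCCS1)C1C(c2ccccc2)=NOC1c1ccccc1` — "not active" (no number reported) in a functional assay, tested at 100 ug/mL; a lower number here means a weaker effect, a higher number a stronger effect of the compound at the concentration tested
compound 2, `COc1ccc(C2=NOC(c3ccc(C)cc3)C2S(=O)(=O)CC2=NCCO2)cc1` — 70.9%
compound 3, `COc1ccc(C2=NOC(c3ccc(C)cc3)C2S(=O)(=O)CC2=NCCS2)cc1` — 52.6%

The study concerns three measured compounds and one that has yet to be tested. Compound 1 `O=S(=O)(CC1=NCCS1)C1C(c2ccccc2)=NOC1c1ccccc1` is reported in this assay as "not active" (no number reported), with no number attached. Compound 2 `COc1ccc(C2=NOC(c3ccc(C)cc3)C2S(=O)(=O)CC2=NCCO2)cc1` gives 70.9%, and compound 3 `COc1ccc(C2=NOC(c3ccc(C)cc3)C2S(=O)(=O)CC2=NCCS2)cc1` gives 52.6%. Compounds 2 and 3 share a core and differ at a single place: a group of 5 heavy atoms (3 carbon, 1 nitrogen, 1 oxygen; one five-membered non-aromatic ring with 2 hetero atoms) in place of a group of 5 heavy atoms (3 carbon, 1 nitrogen, 1 sulfur; one five-membered non-aromatic ring with 2 hetero atoms), on a saturated chain carbon bound to a sulfonyl sulfur. This exchange is worth a number 18.3 percentage points higher from compound 3 to compound 2 (beyond the scatter), a shift that sits outside the usual scatter of the method.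

Compound 4 `O=S(=O)(CC1=NCCO1)C1C(c2ccccc2)=NOC1c1ccccc1` is the unmeasured member. It stands to compound 1 as compound 2 stands to compound 3: a group of 5 heavy atoms (3 carbon, 1 nitrogen, 1 oxygen; one five-membered non-aromatic ring with 2 hetero atoms) in place of a group of 5 heavy atoms (3 carbon, 1 nitrogen, 1 sulfur; one five-membered non-aromatic ring with 2 hetero atoms), on a saturated chain carbon bound to a sulfonyl sulfur. Since the place lines of the two exchanges agree word for word, the two can be called the same change. The cores of compound 1 and compound 3, on the other hand, are not broken down here into a counted difference; they differ by a larger part of the molecule.

Among the compounds with values here, compound 4 is expected to show a step of roughly similar size to the one from compound 3 to compound 2, because that pair gave a number 18.3 percentage points higher from compound 3 to compound 2 (beyond the scatter); the starting point, however, is weaker, since compound 1 is reported as "not active" (no number reported). Compound 4 is therefore estimated at about 25%, with a likely span from 5% to 50%.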

Compound 4, a percentage reported as activity, at one concentration (the size of the read-out at that concentration, not a potency): 56.6%
Beside the measured number, compound 4's estimate is 31.6 percentage points below it; the whole stated range lies below it.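

Within the data shown here, compound 1 stands in this assay as "not active" (no number reported) and carries no number, so no step from compound 1 to compound 4 can be read, although the two differ in one place. The compounds shown leave open whether this exchange changes the read-out by a similar amount on the core of compound 1 and on the core of compound 3. Nothing shown bears on the result for compound 4.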